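From 3-chlorophenyl to 4-aminophenyl: compound 3 to compound 4

The source may hold more compounds than are shown below. What is called first, only, known or untested is meant among the compounds shown, and "the series" means these compounds.

In a functional assay on U2OS cells (Homo sapiens) for cytotoxicity, read by MTT assay, with a stated time of 48 h (on this read-out lower numbers stand for stronger inhibition and higher numbers for weaker inhibition), compound 1 `Fc1cccc(-c2nc(Nc3ccccc3)c3ccccc3n2)c1` gives > 50000 nM, which is a limit and not a number. Compound 2 `Fc1ccc2nc(-c3ccccc3)nc(Nc3ccccc3)c2c1` gives > 50000 nM, again a limit. Compound 3 `Fc1cccc(-c2nc(Nc3cccc(Cl)c3)c3cc(F)ccc3n2)c1` gives > 50000 nM, also a limit. Among the measured compounds shown here, compound 3 therefore stands at the limit of > 50000 nM in this assay, at which 3 of the 3 values shown sit, and no measured compound yet gives a number.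

Compound 4 `Nc1ccc(Nc2nc(-c3cccc(F)c3)nc3ccc(F)cc23)cc1` carries 4-aminophenyl in place of 3-chlorophenyl on a nitrogen on an aromatic ring.

For the measured compounds named here, no measured compound carries the 4-aminophenyl group, and no step between measured compounds is available to size this change. The expectation is therefore loose. A reading in this assay that stays at the limit remains a real possibility. The estimated step is an at least 5.0-fold lower number from compound 3 to compound 4 (0.69 log units; beyond the scatter), expected in the direction of stronger inhibition. For compound 4 the expected value is 10000 nM, with an estimated range of 1500 nM to 50000 nM.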

Compound 4, half-maximal inhibitory concentration: 44200 nM
Compound 4: the middle estimate sits 4.4-fold (0.65 log units) below what was measured; measured number inside the range.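

In this assay, among the compounds shown here, compound 4 gives 44200 nM, the first reading that is a number and not a limit. The step reads as an at least 1.1-fold lower number from compound 3 to compound 4 (0.05 log units; that floor lies within the scatter), so 4-aminophenyl in place of 3-chlorophenyl on this nitrogen is not shown to strengthen inhibition; the result shows only that a compound with a substituent at this position can give a measurable reading in this assay. The other compounds still offer no number for comparison: the limit of > 50000 nM in this assay, at which 3 of the 4 values shown sit.

Going by these compounds, whether the reading in compound 4 depends on the amine itself or on its place on the ring remains open. The same holds for how a 3-aminophenyl or 4-hydroxyphenyl group on this nitrogen would read.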